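A Benzyl Swap on the Core of Compound 1

The source may hold more compounds than are shown below. What is called first, only, known or untested is meant among the compounds shown, and "the series" means these compounds.

In an ADME assay on HepG2 cells (Homo sapiens) for cytotoxicity, read by luminescence, CellTiter-Glo and ATP content, with a stated time of 72 h (on this read-out higher numbers stand for an effect only at larger amounts of compound and lower numbers for an effect already at smaller amounts), compound 1 (`COc1ccc(-c2ccc3c(NCCCNCc4cccc(OC)c4O)ccnc3c2)cc1`) gives 1600 nM. This is the lower of the two numbers available, and compound 2 (`CC(C)Cc1ccc2c(NCCCNCc3ccco3)ccnc2c1`) gives 16000 nM, a gap beyond the usual scatter. Compound 3 (`COc1cccc(CNCCCNc2ccnc3cc(Cc4cc(C)cc(C)c4)ccc23)c1O`) differs from compound 1 in one place, with 3,5-dimethylbenzyl in place of 4-methoxyphenyl on an aromatic carbon. The incoming and outgoing groups each hold one six-membered aromatic ring of carbon only. Within the data shown here, no measured pair isolates this change, and compound 2 differs from compound 1 in more than one place, so the expectation rests on the structural change alone. The estimated step, a 1.1-fold higher number from compound 1 to compound 3 (0.05 log units; within the scatter), is expected to stay within the scatter, with no firm direction in this assay. For compound 3 the expected value is 1800 nM, with an estimated range of 600 nM to 5000 nM.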

Compound 3, half-maximal effective concentration: 2680 nM
The estimate for compound 3 lay 1.5-fold (0.17 log units) below the measured number, within the range that was stated.
By their numbers in this assay, from the lowest: compounds 1 and 3 (each within the scatter of the next); then compound 2.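

In this assay, among these compounds, the swap of 4-methoxyphenyl for 3,5-dimethylbenzyl gives a 1.7-fold higher number from compound 1 to compound 3 (0.22 log units; within the scatter) and is the first step measured at this aromatic carbon, since compound 2 differs from compound 1 in more than one place. Compound 1 and compound 3 cannot be told apart on this read-out, so for this one pair, a ring group carrying an oxygen and a ring group of carbon only give values within the scatter of each other. No available measurement bears on the reason for this result.

The compounds shown leave open how a carboxylic acid or an amine on this carbon would read, and whether a pyridine ring in place of the carbon-only ring would behave alike. They also leave open whether this pair's result would hold with changes elsewhere in compound 1.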